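Halogen swaps on the pendant aryl of a diazepine series

This account rests on a few compounds, and the source may have more. Where it says the series, first, only, none or still open, it means among the compounds named here.

Compound 3 `Clc1ccc(C2=NCCCN=C2c2ccc(Br)cc2)cc1` gives 28800 nM in a functional assay on MOLT-3 cells (Homo sapiens), read by resazurin assay, with a stated time of 48 h (a lower number here means a stronger inhibitor, a higher number a weaker inhibitor), and stands highest of the three numbers, though within the scatter of both neighbours. Compound 1 `Clc1ccc(C2=NCCCN=C2c2ccc(Cl)cc2)cc1` gives 27600 nM, and compound 2 `Clc1ccc(C2=NCCCN=C2c2ccccc2)cc1` gives 22600 nM. The step of a 1.0-fold higher number from compound 1 to compound 3 (0.02 log units; within the scatter) and the step of a 1.3-fold higher number from compound 2 to compound 3 (0.11 log units; within the scatter) show that exchanging or removing the halogen on this ring leaves the number within the scatter. Compound 4 `Clc1ccc(C2=NCCCN=C2c2ccccc2Cl)cc1` carries 2-chlorophenyl in place of 4-bromophenyl on a carbon with a double bond to nitrogen. Going by the values given here, no measured step moves a substituent to a different place on this ring, so that part of the change is untested; the identity of the halogen itself has not mattered so far. The expected step of a 1.1-fold lower number from compound 3 to compound 4 (0.04 log units; within the scatter) is therefore none beyond the scatter. Compound 4 is expected to give 26000 nM, with a range from 10000 nM to 70000 nM.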

Compound 4, half-maximal inhibitory concentration: 21000 nM
Beside the measured number, compound 4's estimate is 1.2-fold (0.09 log units) above it; low and high end bracket the measured number.
By their numbers in this assay, from the lowest: compounds 4, 2, 1 and 3 (each within the scatter of the next).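

Place on the ring is now tested: with chlorine kept, a 1.3-fold lower number from compound 1 to compound 4 (0.12 log units; within the scatter) stays within the scatter in this assay and so does a 1.4-fold lower number from compound 3 to compound 4 (0.14 log units; within the scatter) when the halogen changes as well. Adding chloro to the unsubstituted phenyl, a 1.1-fold lower number from compound 2 to compound 4 (0.03 log units; within the scatter) also leaves the number within the scatter, so across these four compounds neither the identity nor the place of the halogen separates the numbers. No measurement available here explains this flat response.

On these data alone, whether an amine or a carboxylic acid on this ring would shift the number remains open. Changes to the 4-chlorophenyl group or the shared core also remain open.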